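The source may hold more compounds than are shown below. What is called first, only, known or untested is meant among the compounds shown, and "the series" means these compounds.

Compound 2 `O=C1O[C@@H](CSc2cccs2)CN1c1ccc(-n2cc(-c3ccccn3)cn2)c(F)c1` carries the only number shown in a physicochemical assay for solubility, read by HPLC, with a stated time of 24 h (on this read-out lower numbers stand for lower solubility and higher numbers for higher solubility), where compound 2 gives 8500 nM. Compound 1 `O=C(OC[C@H]1CN(c2ccc(-n3cc(-c4ccccn4)cn3)c(F)c2)C(=O)O1)c1ccccc1` stands at a limit of this assay, <= 65400 nM, a limit and not a number. The step that the limit leaves unreadable from compound 1 to compound 2 is therefore unreadable, and the line the limit of <= 65400 nM in this assay, at which 1 of the 2 values shown sits, marks where that limit sits. Compound 3 `O=C(NC[C@H]1CN(c2ccc(-n3cc(-c4ccccn4)cn3)c(F)c2)C(=O)O1)C(F)F` differs from compound 2 by ((difluoromethyl)carbonyl)amino in place of (thiophen-2-yl)sulfanyl on a saturated chain carbon bound to a saturated ring carbon. No measured step bears readably on this change, so the direction rests on no shown step. Compound 3 is estimated at 30000 nM, within 8000 nM to 120000 nM, which means an expected step of a 3.5-fold higher number from compound 2 to compound 3 (0.55 log units; beyond the scatter).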

Compound 3, solubility: 29900 nM
Compound 3: middle estimate off by 1.0-fold (0.00 log units), on the high side, within the range that was stated.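

In this assay this position now has a readable step, on a saturated chain carbon bound to a saturated ring carbon: ((difluoromethyl)carbonyl)amino in place of (thiophen-2-yl)sulfanyl gives a 3.5-fold higher number from compound 2 to compound 3 (0.55 log units; beyond the scatter). The change removes a five-membered aromatic ring and brings in a hydrogen-bond donor, and this single step cannot separate the two. Compound 1 stands at a limit and not a number, so its steps to the other compounds cannot be read: the limit of <= 65400 nM in this assay, at which 1 of the 3 values shown sits.

Which part of the exchange carries the step remains open. On these data alone, how an amine or a carboxylic acid would read at this place also remains open.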